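A few compounds are considered here, and "the series" means these few. Any claim that something is new, unique, unknown or untested is made for them only; others in the source may bear on it.

Measured so far:
compound 1, `CCO/C(O)=C1\C(COCCn2cc(N)n(C)c2=O)=NC(C)=C(C(=O)OC)C1c1ccccc1Cl`: 25.1 nM
compound 2, `CCO/C(O)=C1\C(COCCn2c(C)nc(C)c2C)=NC(C)=C(C(=O)OC)C1c1ccccc1Cl`: 5.01 nM

Of these two numbers in a functional assay (aorta) with Rattus norvegicus as the target (a lower number here means a stronger inhibitor, a higher number a weaker inhibitor), compound 2 holds the lower one; the step of a 5.0-fold lower number from compound 1 to compound 2 (0.70 log units; beyond the scatter) lies beyond the scatter, so compound 2 is the stronger inhibitor of the pair. Compound 3, `CCO/C(O)=C1\C(COCCn2ccnc2C)=NC(C)=C(C(=O)OC)C1c1ccccc1Cl`, differs from compound 2 in one place: 2-methyl-1H-imidazol-1-yl in place of 2,4,5-trimethyl-1H-imidazol-1-yl on a saturated chain carbon, two bonds along the chain from an oxygen on a saturated carbon. Among the measured compounds shown here, only one measured step exists, a 5.0-fold lower number from compound 1 to compound 2 (0.70 log units; beyond the scatter), and it swaps one whole ring for a ring of a different kind, whereas the change to compound 3 keeps the same ring and removes two of its methyl groups. That step therefore bears only loosely on the present change. With no closer guide, a small step is expected, likely toward a slightly higher number, within or near the scatter: a 1.6-fold higher number from compound 2 to compound 3 (0.20 log units; within the scatter). For compound 3 the expected value in this assay is 8 nM, estimated to lie between 3 nM and 25 nM.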

Compound 3, half-maximal inhibitory concentration: 2.51 nM
For compound 3 the middle estimate is 3.2-fold (0.50 log units) above the measured one; measured number outside the range, below it.
By their numbers in this assay, from the lowest: compounds 3 and 2 (each within the scatter of the next); then compound 1.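

In this assay the two extra ring methyl groups that set 2,4,5-trimethyl-1H-imidazol-1-yl apart from 2-methyl-1H-imidazol-1-yl leave no difference that can be told from scatter, with a 2.0-fold lower number from compound 2 to compound 3 (0.30 log units; within the scatter) as the printed step, so this position accepts either group on the present data. The ring carried by compound 1 stands clearly apart, with a 10-fold lower number from compound 1 to compound 3 (1.00 log units; beyond the scatter) as a step beyond the scatter, which shows that ring type counts for more here than these two methyl groups do. No supporting measurement is available to explain either result.

Going by these compounds, it remains open whether plain 1H-imidazol-1-yl, with no methyl group at all, would match these two compounds, and whether 2,4-dimethyl-1H-imidazol-1-yl would also fit. A longer chain between the oxygen and the 2-methyl-1H-imidazol-1-yl ring is also untested among the compounds shown.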